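From Methyl to Methoxy on a Long-Lived Compound

A few compounds are considered here, and "the series" means these few. Any claim that something is new, unique, unknown or untested is made for them only; others in the source may bear on it.

In an unclassified assay for pharmacokinetics, read by NMR, tested at 2 mg/mL (on this read-out lower numbers stand for a shorter-lived compound and higher numbers for a longer-lived compound), compound 3 (`COc1n[nH]c2ncc(NC(=O)c3c(F)ccc(/N=N\c4ccccc4C)c3F)cc12`) gives > 70 h as a limit and not as a number. Compound 2 (`COc1n[nH]c2ncc(NC(=O)c3c(F)ccc(/N=N\c4ccc(C)cc4)c3F)cc12`) gives > 20 h as a limit too. So all the results known so far, including the one discussed below, are limits, and no firm ranking can be read from them.

Compound 4 (`COc1ccccc1/N=N\c1ccc(F)c(C(=O)Nc2cnc3[nH]nc(OC)c3c2)c1F`) differs from compound 3 by a single group, with methoxy in place of methyl on an aromatic carbon, ortho to a large group (methoxy in place of methyl on an aromatic carbon) which turns 2-methylphenyl into 2-methoxyphenyl. The same two groups are exchanged in the opposite sense in a step that the two limits leave unreadable from compound 1 to compound 2 and the 2-methylphenyl group arrives in a step that the two limits leave unreadable from compound 2 to compound 3 but neither gives a size to carry over.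

For the measured compounds named here, the only hint is that compound 1 (`COc1ccc(/N=N\c2ccc(F)c(C(=O)Nc3cnc4[nH]nc(OC)c4c3)c2F)cc1`), the sole measured compound with methoxy, holds the limit > 10 h so a modest shift toward a shorter-lived compound is expected. The estimated move is an at least 1.7-fold lower number from compound 3 to compound 4 (0.24 log units; that floor lies within the scatter) and it remains uncertain. Compound 4 is expected at 40 h within an estimated range of 12 h to 120 h.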

Compound 4, half-life: > 24 h
Compound 4 gave a limit, no number; the forecaster's own chance of this, stated with the estimate: 60%; the middle value is on the limit's open side.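

In this assay compound 4 gives > 24 h, which is a limit and not a number. For the compounds shown here, compound 1, compound 2 and compound 3 are also known only as limits, so no step to compound 4 can be read. Still open, on these data alone, is the actual half-life of each compound, and whether methoxy in place of methyl changes it at all.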